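The compounds below may be only part of what the source reports. "The series", "measured", "known", "first", "only" and "open" are said of these compounds alone.

Three compounds of the series carry numbers in a functional assay on MIA PaCa-2 cells (Homo sapiens) for cytotoxicity, read by MTT assay, with a stated time of 72 h; on this read-out higher numbers stand for weaker inhibition and lower numbers for stronger inhibition. Compound 1 `COc1ccc(-c2ccc(NC3=CC(=O)c4ncncc4C3=O)cc2)cc1` gives 2100 nM, compound 2 `CCc1ccc(-c2ccc(NC3=CC(=O)c4ncncc4C3=O)cc2)cc1` gives 2000 nM and compound 3 `NC(=O)c1ccc(NC2=CC(=O)c3ncncc3C2=O)cc1` gives 8000 nM. The step of a 1.1-fold lower number from compound 1 to compound 2 (0.02 log units; within the scatter) exchanges ethyl for methoxy on an aromatic carbon and stays within the scatter. The steps of a 3.8-fold higher number from compound 1 to compound 3 (0.58 log units; beyond the scatter) and a 4.0-fold higher number from compound 2 to compound 3 (0.60 log units; beyond the scatter) each replace a substituted phenyl by carbamoyl and both lie beyond the scatter, so compound 3 holds the highest number of the three, with compound 1 nearest and compound 2 furthest. Compound 4 `NS(=O)(=O)c1ccc(NC2=CC(=O)c3ncncc3C2=O)cc1` differs from compound 3 by sulfamoyl in place of carbamoyl on an aromatic carbon. For the measured compounds named here, no measured step exchanges one non-ring group for another on the same aromatic carbon; the two steps that end at compound 3 concern the loss of a 4-methoxyphenyl or 4-ethylphenyl group and say nothing about what follows once carbamoyl is already in place. Going by the values given here, with no step in this assay bearing directly on this exchange, the expected step for compound 4 is no change at the digits printed from compound 3 to compound 4 (within the scatter), no larger than the usual scatter in either direction. Compound 4 is accordingly estimated at 8000 nM, with a range from 3000 nM to 20000 nM in this assay.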

Compound 4, half-maximal inhibitory concentration: > 10000 nM
Compound 4 ended at the assay's limit (the forecaster's own chance of this, stated with the estimate: 10%); middle value at least 1.2-fold (0.09 log units) away from the limit.
By their numbers in this assay, from the lowest: compounds 2 and 1 (each within the scatter of the next); then compound 3. At a limit, above all of these: compound 4.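

In this assay compound 4 gives > 10000 nM, which is a limit of the assay and not a number. Sulfamoyl in place of carbamoyl on this aromatic carbon, para to a large group, gives an at least 1.2-fold higher number from compound 3 to compound 4 (0.09 log units; that floor lies within the scatter), so the floor of the step does not separate the two groups and sets no upper bound on the exchange. The steps of an at least 4.7-fold higher number from compound 1 to compound 4 (0.67 log units; beyond the scatter) and an at least 5.0-fold higher number from compound 2 to compound 4 (0.69 log units; beyond the scatter) both lie beyond the scatter, so the sulfamoyl compound, like the carbamoyl compound, stands higher than the two compounds with a 4-methoxyphenyl or 4-ethylphenyl group at this place, and none of the four compounds goes against this.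

Still open, from the compounds shown here alone, is how far past the limit compound 4 lies, and so whether sulfamoyl and carbamoyl truly differ beyond the scatter on this carbon. Also open, going by these compounds, is whether a carboxylic acid, a primary amine or a methyl ester at the same aromatic carbon would give a number inside the range of this assay, and where such a number would fall relative to compound 3.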